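Cytotoxicity notes: from compound 2 to compound 4

The source may report more compounds than this note shows. Statements on the series, on what has been measured and on what is new or still open speak of the compounds shown alone.

Measured so far in an ADME assay on Akata cells (Homo sapiens) for cytotoxicity, with a stated time of 7 days; a lower number here means that less compound is tolerated, a higher number that more compound is tolerated:
- compound 1 `CCCCSc1nc(N)nc2c1ncn2/C=C1/CC1(CO)CO` gives only the limit > 20000 nM.
- compound 2 `CC(C)CSc1nc(N)nc2c1ncn2/C=C1/CC1(CO)CO` gives only the limit > 20000 nM.
- compound 3 `CCCNc1nc(N)nc2c1ncn2/C=C1/CC1(CO)CO` gives only the limit > 24000 nM.

Every value in this assay is a limit of the assay and not a number. Compound 2 therefore stands at a limit, and the two further values shown are limits as well; two of the three values sit at the limit of > 20000 nM in this assay, at which 2 of the 3 values shown sit, and one at the limit of > 24000 nM in this assay, at which 1 of the 3 values shown sits. None of the three measured steps can be read: a step that the two limits leave unreadable from compound 1 to compound 2, a step that the two limits leave unreadable from compound 1 to compound 3 and a step that the two limits leave unreadable from compound 2 to compound 3 are all left unreadable by the two limits, so no size and no direction are known for any change in this series.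

The next compound, compound 4 `CCCCCCSc1nc(N)nc2c1ncn2/C=C1/CC1(CO)CO`, differs from compound 2 in one place: pentyl in place of isopropyl on a saturated chain carbon bound to a sulfur. Within the data shown here, the only measured step at the same place is the one from compound 1 to compound 2, and it is unreadable; the two others bear on a different place and are unreadable too. Nothing measured here therefore points to a readable step in this assay, and the expectation is that compound 4 will again sit at or beyond the limit. Compound 4 is thus expected to give about 25000 nM, with a range from 8000 nM to 80000 nM, which corresponds to an expected step that the limit leaves unreadable from compound 2 to compound 4.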

Compound 4, half-maximal cytotoxic concentration: > 20000 nM
Compound 4: only a limit was reported (the forecaster's own chance of this, stated with the estimate: 75%); the middle value does not contradict the limit.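

In this assay compound 4 gives > 20000 nM as a limit of the assay and not a number. Its steps from compound 1, compound 2 and compound 3 therefore cannot be read. The compounds shown leave open where any of the four true values lies and whether changing the group at this place alters cytotoxicity at all.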